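Working notes: replacing the amino side group of compound 3

The compounds below may be only part of what the source reports. "The series", "measured", "known", "first", "only" and "open" are said of these compounds alone.

- compound 1 `CC1(C)CCC(CN2CCN(c3ccc(C(=O)NS(=O)(=O)c4ccc(NCC5CCOCC5)c([N+](=O)[O-])c4)c(Oc4cnc5[nH]ccc5c4)c3)CC2)=C(c2ccc(Cl)cc2C(F)(F)F)C1` - 74 nM
- compound 2 `CC1(C)CCC(CN2CCN(c3ccc(C(=O)NS(=O)(=O)c4ccc(NCC5CCOCC5)c([N+](=O)[O-])c4)c(Oc4cnc5[nH]ccc5c4)c3)CC2)=C(c2cccc(C(F)(F)F)c2)C1` - 63 nM
- compound 3 `CC1(C)CCC(CN2CCN(c3ccc(C(=O)NS(=O)(=O)c4ccc(NCC5CCOC5)c([N+](=O)[O-])c4)c(Oc4cnc5[nH]ccc5c4)c3)CC2)=C(c2ccc(C(F)(F)F)cc2)C1` - 24.2 nM

In a functional assay on RS4-11 cells (Homo sapiens) for inhibition, read by CCK-8 assay, with a stated time of 72 h (on this read-out higher numbers stand for weaker inhibition and lower numbers for stronger inhibition), compound 3 gives 24.2 nM, the lowest number of the three, and compound 2 and compound 1 both lie higher by more than the scatter.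

The next structure is compound 4 `CC(Oc1ccc(S(=O)(=O)NC(=O)c2ccc(N3CCN(CC4=C(c5ccc(C(F)(F)F)cc5)CC(C)(C)CC4)CC3)cc2Oc2cnc3[nH]ccc3c2)cc1[N+](=O)[O-])C1CCOCC1`, and the change is a group of 9 heavy atoms (7 carbon, 2 oxygen; one six-membered non-aromatic ring with 1 hetero atom) in place of a group of 7 heavy atoms (5 carbon, 1 nitrogen, 1 oxygen; one five-membered non-aromatic ring with 1 hetero atom), on an aromatic carbon. It sits ortho to a nitro group and para to a large group.

Going by the values given here, the only measured single-place step, a 1.2-fold lower number from compound 1 to compound 2 (0.07 log units; within the scatter), lies within the scatter. It concerns the aryl group on a double-bonded ring carbon, so it gives no size for the present change. Among the compounds with values here, no measured compound carries the entering group, and no measured step in this assay covers this place alone.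

A weak hint comes from compound 2 at 63 nM and compound 1 at 74 nM. Both also hold a six-membered non-aromatic ring with 1 hetero atom in this group and read higher than compound 3, yet both differ from compound 3 in a second place as well.

A small expected move toward a higher number is estimated as a 1.7-fold higher number from compound 3 to compound 4 (0.22 log units; within the scatter), with wide uncertainty. For compound 4 the estimated value is 40 nM, with an expected range of 12 nM to 130 nM.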

Compound 4, half-maximal inhibitory concentration: 269 nM
The estimate for compound 4 lay 6.7-fold (0.83 log units) below the measured number; measured number outside the range, above it.
By their numbers in this assay, from the lowest: compound 3; then compounds 2 and 1 (each within the scatter of the next); then compound 4.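

Notes on the aromatic carbon ortho to a nitro group: in this assay, exchanging the ((oxolan-3-yl)methyl)amino group for the larger entering group gives an 11-fold higher number from compound 3 to compound 4 (1.05 log units; beyond the scatter), a large step beyond the scatter, which shows that this position strongly affects the read-out for this change. Going by these compounds alone, the only earlier single-place step, a 1.2-fold lower number from compound 1 to compound 2 (0.07 log units; within the scatter), concerned the aryl group on a double-bonded ring carbon and gave no reading at this position. The change combines several differences, going from a five-membered to a six-membered non-aromatic ring, from 7 to 9 heavy atoms, and from 1 hydrogen-bond donor to 0 hydrogen-bond donors, and no information at hand bears on the cause of the step.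

Which of these differences carries the step remains open, as no pair shown separates the ring size from the loss of the hydrogen-bond donor. Also open, from the compounds shown here alone, is how a group without a ring, such as a 2-methoxyethylamino chain, would read on this aromatic carbon.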